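Carbamate to Amide: Where Compound 3 Might Land

The source may report more compounds than this note shows. Statements on the series, on what has been measured and on what is new or still open speak of the compounds shown alone.

Compound 1 `CC(C)(C)OC(=O)N1CCC(n2ncc3c(Oc4ccc(S(C)(=O)=O)cc4)ncnc32)CC1` and compound 2 `CC(C)OC(=O)N1CCC(n2ncc3c(Oc4ccc(S(C)(=O)=O)cc4)ncnc32)CC1` share one core and differ in a single group. In a physicochemical assay for solubility, measured as kinetic solubility, at pH 6.5 (a higher number here means a more soluble compound, a lower number a less soluble compound), compound 1 gives < 1 ug/mL, a limit of the assay rather than a number. In this assay compound 2 gives < 1 ug/mL, again a limit. Among the measured compounds shown here, the one measured step, a step that the two limits leave unreadable from compound 1 to compound 2, is thus not readable in size, and both values sit at the limit of < 1 ug/mL in this assay, at which 2 of the 2 values shown sit. Compound 3 `CC(C)CC(=O)N1CCC(n2ncc3c(Oc4ccc(S(C)(=O)=O)cc4)ncnc32)CC1` differs from compound 2 by isobutyl in place of isopropoxy on a carbonyl carbon. For the measured compounds named here, no measured step matches this change, so compound 2 offers only a ceiling as a starting point, and nothing in the measured pair points in either direction. Compound 3 is therefore expected to stay near that ceiling, with the step of a number no lower from compound 2 to compound 3 (the limit leaves the size open) estimated to be small relative to the scatter. The estimate for compound 3 is 1 ug/mL, expected between 0.3 ug/mL and 4 ug/mL.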

Compound 3, solubility: 32 ug/mL
For compound 3 the middle estimate is 32-fold (1.51 log units) below the measured one, outside the stated range (above it).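

In this assay, isobutyl in place of isopropoxy on the carbonyl carbon gives an at least 32-fold higher number from compound 2 to compound 3 (1.50 log units; beyond the scatter), and isobutyl in place of tert-butoxy gives an at least 32-fold higher number from compound 1 to compound 3 (1.50 log units; beyond the scatter). This position, on a carbonyl carbon bearing an amide-type nitrogen in a ring, can therefore move the read-out by a large step, with isobutyl holding 4 carbons where isopropoxy holds 3 carbons and 1 oxygen. Compound 1 and compound 2 could not show this, and the step between them cannot be read: the limit of < 1 ug/mL in this assay, at which 2 of the 3 values shown sit.

Going by these compounds, how far compound 1 and compound 2 lie beneath their shared limit stays open, so the full size of both new steps is unknown. Also open, on these data alone, is whether the step belongs to isobutyl alone or would hold for a longer chain, a cyclopropyl group or an amine on the same carbonyl carbon.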